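The source may report more compounds than this note shows. Statements on the series, on what has been measured and on what is new or still open speak of the compounds shown alone.

Compound 1 `CS(=O)(=O)N(CCCO)c1c(Cl)c(Cl)cc2[nH]c(=O)c(=O)[nH]c12`: 1%
Compound 2 `Cc1cc2[nH]c(=O)c(=O)[nH]c2c(N(CC(=O)O)S(C)(=O)=O)c1Cl`: 5%

In an in vivo ADME assay on the whole organism (strain Sprague-Dawley) for pharmacokinetics, with Rattus norvegicus as the target, at a dose of 5 mg/kg by the oral route (on this read-out lower numbers stand for lower oral bioavailability and higher numbers for higher oral bioavailability), compound 1 gives 1% and compound 2 gives 5%, so the two lie within the usual scatter of each other and neither can be ranked. Compound 3 `CC(O)CN(c1c(Cl)c(Cl)cc2[nH]c(=O)c(=O)[nH]c12)S(C)(=O)=O` has the same atoms as compound 1, joined differently: 1-hydroxyethyl in place of 2-hydroxyethyl on a saturated chain carbon bound to a sulfonamide nitrogen. This places 1-hydroxyethyl in place of 2-hydroxyethyl on a saturated chain carbon bound to a sulfonamide nitrogen. Among the measured compounds shown here, no measured pair shows what such a change does, so no shift beyond the scatter is expected, and the expected move is a number 3 percentage points higher from compound 1 to compound 3 (within the scatter). For compound 3 the estimated value is 4%, with an expected range from 1% to 15%.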

Compound 3, oral bioavailability in the Rattus norvegicus assay: 1%
Compound 3: middle estimate off by 3 percentage points, on the high side; the range from low to high includes it.
By their numbers in the Rattus norvegicus assay, from the lowest: compounds 1, 3 and 2 (each within the scatter of the next).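

Among the compounds shown here, in the Rattus norvegicus assay compound 1 gives 1% and compound 3 gives 1%, and the first measured step at this place, 1-hydroxyethyl in place of 2-hydroxyethyl on a saturated chain carbon bound to a sulfonamide nitrogen, shows no change at the digits printed from compound 1 to compound 3 (within the scatter). In a physicochemical assay for solubility (on this read-out lower numbers stand for lower solubility and higher numbers for higher solubility), compound 1 gives 76 ug/mL and compound 3 gives 76 ug/mL, and the same change shows no change at the digits printed from compound 1 to compound 3 (within the scatter), so neither read-out separates the two arrangements of the chain. No measurement is available that would explain this result.

Still open, going by these compounds, is whether an amine or a longer chain at this place would shift either read-out. Compound 2 differs from compound 1 in more than one place, so it cannot settle that.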